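Amino in place of hydrogen on compound 1

A few compounds are considered here, and "the series" means these few. Any claim that something is new, unique, unknown or untested is made for them only; others in the source may bear on it.

Measured so far in a functional assay on HepG2 cells (Homo sapiens) for antiproliferative activity, read by XTT assay, with a stated time of 72 h; on this read-out lower numbers stand for stronger inhibition and higher numbers for weaker inhibition
Compound 1 `COc1ncnc2c1c(-c1ccccc1)cn2[C@@H]1O[C@H](CO)[C@@H](O)[C@H]1O` gives > 20000 nM
Compound 2 `CNc1ncnc2c1c(-c1ccccc1)cn2[C@@H]1O[C@H](CO)[C@@H](O)[C@H]1O` gives > 20000 nM

Compound 1 stands at > 20000 nM in this series, and that entry is a limit of the assay and not a number. The entry for compound 2 is a limit as well. The record so far therefore amounts to the limit of > 20000 nM in this assay, at which 2 of the 2 values shown sit, and holds no actual number.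

Compound 3 `COc1nc(N)nc2c1c(-c1ccccc1)cn2[C@@H]1O[C@H](CO)[C@@H](O)[C@H]1O` keeps the core of compound 1 and the methoxy group, and it carries amino in place of hydrogen on an aromatic carbon, between two ring nitrogen atoms. The change counts as amino in place of hydrogen on an aromatic carbon in full.

For the measured compounds named here, the one measured step is a step that the two limits leave unreadable from compound 1 to compound 2 and it alters the methoxy group, which compound 3 retains. It gives no size and no direction to carry over to the new amino group. No step beyond the scatter is therefore expected in this assay and compound 3 will most likely also be reported as a limit. The expected outcome is a number no higher from compound 1 to compound 3 (the limit leaves the size open) on this estimate. For compound 3 the estimated value is 20000 nM with an expected range from 7000 nM to 40000 nM in this read-out.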

Compound 3, half-maximal inhibitory concentration: > 20000 nM
Compound 3: no number, only a limit; the forecaster's own chance of this, stated with the estimate: 75%; the middle value lies on the limit itself.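

In this assay compound 3 gives > 20000 nM as a limit of the assay and not a number. With limits on both sides, no step can be read from compound 1 to compound 3 or between compounds 2 and 3. The record stays as it was: the limit of > 20000 nM in this assay, at which 3 of the 3 values shown sit. The compounds shown leave open how far the amino group, or either other variation on the shared core, moves the actual potency.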